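This account rests on a few compounds, and the source may have more. Where it says the series, first, only, none or still open, it means among the compounds named here.

Compounds measured so far in a functional assay on HL-60 cells (Homo sapiens) for cytotoxicity, read by MTT assay (a higher number here means a weaker inhibitor, a lower number a stronger inhibitor), are as follows
Compound 1 (`COc1ccc(S(=O)(=O)NC(C2=CC(=O)c3c(O)ccc(O)c3C2=O)C(C)C)cc1`) gives "not determined" (no result reported)
Compound 2 (`CC(C)C(NS(=O)(=O)c1ccc(F)cc1)C1=CC(=O)c2c(O)ccc(O)c2C1=O`) gives "not determined" (no result reported)
Compound 3 (`COc1ccc(S(=O)(=O)NC(C)C2=CC(=O)c3c(O)ccc(O)c3C2=O)cc1`) gives 20 nM

Among the measured compounds shown here, only one number is therefore available. Compound 3 stands alone at 20 nM in this series, while the two other entries carry no result, so it cannot be ranked against either of them. The next compound to be tested is compound 4 (`CC(NS(=O)(=O)c1ccccc1Br)C1=CC(=O)c2c(O)ccc(O)c2C1=O`), which has not yet been measured. It shares the core of compound 3 and differs from it in one place (2-bromophenyl in place of 4-methoxyphenyl on a sulfonyl sulfur), with 2-bromophenyl in place of 4-methoxyphenyl on a sulfonyl sulfur.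

For the measured compounds named here, no step between two measured compounds exists to show how much such an exchange matters in this assay, and the size of the change can only be judged loosely. Compound 3 at 20 nM already sits at a low number, so a moderate loss seems more likely than a further gain, though a result within the usual scatter would be no surprise. The estimate therefore means an expected shift towards weaker inhibition, a 2.5-fold higher number from compound 3 to compound 4 (0.40 log units; beyond the scatter) in size. The estimated value for compound 4 is 50 nM with an expected range from 12 nM to 250 nM when it is measured.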

Compound 4, half-maximal inhibitory concentration: 120 nM
Estimate against measurement, compound 4: 2.4-fold (0.38 log units) below, within the range that was stated.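

Among the compounds shown here, replacing 4-methoxyphenyl with 2-bromophenyl on a sulfonyl sulfur whose other neighbour is the sulfonamide nitrogen gives a 6.0-fold higher number from compound 3 to compound 4 (0.78 log units; beyond the scatter) in this assay, the first step that can be read. It shows that the group at this position is not interchangeable in this assay, since this exchange moves the result beyond the usual scatter and towards weaker inhibition, although compound 4 still gives a value of 120 nM. No measurement at hand bears on why the exchange has this effect, so the step remains an observation about these two groups alone.

The single step changes both the substituent on the phenyl ring and the number of its place, so the compounds shown cannot separate the bromine from its location, a question that 4-bromophenyl or 2-methoxyphenyl at the same position would address. They also leave open how an unsubstituted phenyl, a pyridyl ring or a simple alkyl chain on the sulfonyl sulfur would compare with the two aryl groups seen so far.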